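The source may report more compounds than this note shows. Statements on the series, on what has been measured and on what is new or still open speak of the compounds shown alone.

Compound 1 `O=c1cc(I)n([C@@H]2O[C@H](CO)[C@@H](O)[C@H]2O)c(=O)[nH]1` carries an iodo group on the shared core, and in a functional assay on LOX cells (Homo sapiens) for antiproliferative activity, read by WST assay, with a stated time of 3 days (on this read-out lower numbers stand for stronger inhibition and higher numbers for weaker inhibition), compound 1 reaches only the limit of the assay, > 50000 nM, not a number. Compound 2 `[N-]=[N+]=Nc1cc(=O)[nH]c(=O)n1[C@@H]1O[C@H](CO)[C@@H](O)[C@H]1O` arises from compound 1 by azido in place of iodo on an aromatic carbon, and in this assay compound 2 likewise gives only the limit > 50000 nM. Hence a step that the two limits leave unreadable from compound 1 to compound 2. Compound 3 `O=c1[nH]c(=O)n([C@@H]2O[C@H](CO)[C@@H](O)[C@H]2O)c(I)c1F` differs from compound 1 by fluoro in place of hydrogen on an aromatic carbon, and in this assay compound 3 again gives only the limit > 50000 nM; accordingly a step that the two limits leave unreadable from compound 1 to compound 3. All three results share one feature: the limit of > 50000 nM in this assay, at which 3 of the 3 values shown sit.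

Compound 4 `[N-]=[N+]=Nc1c(F)c(=O)[nH]c(=O)n1[C@@H]1O[C@H](CO)[C@@H](O)[C@H]1O` has not been measured. It stands to compound 3 as compound 2 stands to compound 1, the same kind of change, (azido in place of iodo on an aromatic carbon); the place differs from the earlier one in being ortho to a fluoro group, while the cores of compound 1 and compound 3 differ by the fluoro in place of hydrogen described above. Because both compound 1 and compound 2 sit at the limit of > 50000 nM in this assay, at which 3 of the 3 values shown sit, the expected step is a step that the limit leaves unreadable from compound 3 to compound 4, with the size unknowable from these limits. Compound 4 is therefore estimated at 100000 nM in this assay, with 50000 nM to 500000 nM as the expected range, most likely again reported only as a limit.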

Compound 4, half-maximal inhibitory concentration: 2300 nM
Beside the measured number, compound 4's estimate is 43-fold (1.64 log units) above it; measured number below the stated range.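

In this assay, azido in place of iodo, ortho to a fluoro group, gives an at least 21-fold lower number from compound 3 to compound 4 (1.33 log units; beyond the scatter), and fluoro in place of hydrogen on the azido-bearing core gives an at least 21-fold lower number from compound 2 to compound 4 (1.33 log units; beyond the scatter), so the two groups together give the only readable number among the compounds shown. Among the compounds shown here, the same azido change on the core of compound 1 yields no readable number, and the remaining steps among the earlier compounds cannot be read either, because each of those compounds gives only a limit: the limit of > 50000 nM in this assay, at which 3 of the 4 values shown sit. This shows that the azido change did not carry from one core to the other as a measurable result, but it does not show how much the step differs between the cores, since the true values behind the limits are unknown.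

The compounds shown leave open whether azido itself is needed at this place, as no amine, nitrile or chloro group stands there beside the fluoro group. They also leave open whether fluoro is the only partner that works, as no chloro or methyl group stands in its place.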